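The source may hold more compounds than are shown below. What is called first, only, known or untested is meant among the compounds shown, and "the series" means these compounds.

Measured so far in an ADME assay on microsomes from liver (Homo sapiens) for metabolic stability, read by LC-MS, using NADPH, with stated times of 5 min and 30 min, tested at 1 uM; a higher number here means faster removal of the compound, a lower number slower removal:
- compound 1 `Cn1nccc1-c1cnc(NCc2c(F)ccc3c2CCO3)c2cn[nH]c(=O)c12`: 14 mL.min-1.g-1
- compound 2 `Cc1nc(CN(C)C)ccc1-c1cnc(NCc2c(F)ccc3c2CCO3)c2cn[nH]c(=O)c12`: 13 mL.min-1.g-1

The two numbers lie within the scatter of each other, so compound 2 stands level with compound 1. Compound 3 `Cc1ncccc1-c1cnc(NCc2c(F)ccc3c2CCO3)c2cn[nH]c(=O)c12` is compound 2 with one change: hydrogen in place of (dimethylamino)methyl on an aromatic carbon. Among the measured compounds shown here, the only measured step that bears on this, a 1.1-fold lower number from compound 1 to compound 2 (0.03 log units; within the scatter), exchanged the whole group carrying that chain and stayed within the scatter. No step beyond the scatter is therefore expected in this assay. The estimated 1.2-fold higher number from compound 2 to compound 3 (0.06 log units; within the scatter) reflects this. Compound 3 is expected at 15 mL.min-1.g-1, with an estimated range of 8 mL.min-1.g-1 to 28 mL.min-1.g-1.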

Compound 3, intrinsic clearance in microsomes: 41 mL.min-1.g-1
Compound 3: middle estimate off by 2.7-fold (0.44 log units), on the low side, outside the stated range (above it).
By their numbers in this assay, from the lowest: compounds 2 and 1 (each within the scatter of the next); then compound 3.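

In this assay, the (dimethylamino)methyl group on the six-membered aromatic ring with 1 nitrogen proves to matter: hydrogen in its place gives a 3.2-fold higher number from compound 2 to compound 3 (0.50 log units; beyond the scatter). The 2-methylpyridin-3-yl group without that chain also separates from the 1-methyl-1H-pyrazol-5-yl group, with a 2.9-fold higher number from compound 1 to compound 3 (0.47 log units; beyond the scatter). The level numbers of compound 1 and compound 2 alone did not reveal either difference.

Nothing available explains the rise in clearance. From the compounds shown here alone, whether a shorter amine or a carboxylic acid at this place would also keep the number low remains open.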